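This account rests on a few compounds, and the source may have more. Where it says the series, first, only, none or still open, it means among the compounds named here.

Measured so far in an assay on HEK293 cells for inhibition of protein deacetylase HDAC6 (Homo sapiens); a higher number here means a weaker inhibitor, a lower number a stronger inhibitor:
compound 2 `CCCC(=S)SCC(=O)c1ccc(OC)cc1` gives 110 nM
compound 1 `COc1ccc(C(=O)CSC(=S)SCCOc2ccccc2)cc1` gives 4570 nM

Compound 2 stands at the lowest of these two numbers, and its gap to compound 1 lies beyond the scatter. Compound 3, `COc1ccc(C(=O)CSC(=S)SCCNC(C)=O)cc1`, is not yet measured; it differs from compound 2 by (2-acetamidoethyl)sulfanyl in place of propyl on a thiocarbonyl carbon. Within the data shown here, no measured pair shares this change. Compound 3 now has more in common with compound 1 than compound 2 does, and compound 1 gives 4570 nM, so the step is expected to weaken inhibition clearly, a 14-fold higher number from compound 2 to compound 3 (1.13 log units; beyond the scatter). Compound 3 is therefore estimated at 1500 nM, with a range from 300 nM to 6000 nM.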

Compound 3, half-maximal inhibitory concentration: 1640 nM
Beside the measured number, compound 3's estimate is 1.1-fold (0.04 log units) below it; the range from low to high includes it.
By their numbers in this assay, from the lowest: compound 2; then compound 3; then compound 1.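

In this assay, replacing propyl on the thiocarbonyl carbon with (2-acetamidoethyl)sulfanyl gives a 15-fold higher number from compound 2 to compound 3 (1.17 log units; beyond the scatter), so inhibition here is clearly weaker with this sulfur-linked chain. The far end of the chain matters too: acetamido in place of phenoxy gives a 2.8-fold lower number from compound 1 to compound 3 (0.45 log units; beyond the scatter), a modest gain that leaves inhibition well short of compound 2. Nothing available explains either step.

Still open, going by these compounds, is how an amine or a carboxylic acid at the end of that chain would compare. It is also unknown whether a butyl chain on the thiocarbonyl carbon would keep inhibition as strong as in compound 2.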